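Removing a cyclopropyl: from compound 3 to compound 4

The source may hold more compounds than are shown below. What is called first, only, known or untested is meant among the compounds shown, and "the series" means these compounds.

compound 1 `CC1CCN(C2CCN(S(=O)(=O)c3ccc(F)cc3F)CC2)CC1` — in an ADME assay on HCT-116 cells (Homo sapiens) for cytotoxicity, read by CellTiter-Glo, with a stated time of 72 h (a lower number here means a stronger inhibitor, a higher number a weaker inhibitor), compound 1 shows only a limit, > 5000 nM
compound 2 `CC1CCN(C2CCN(S(=O)(=O)c3cccnc3Cl)CC2)CC1` — in this assay compound 2 shows only a limit, > 10000 nM
compound 3 `CC1CCN(C2CCN(S(=O)(=O)c3sc(Cl)nc3C3CC3)CC2)CC1` — in this assay compound 3 shows only a limit, > 10000 nM

Compound 3 stands at the limit of > 10000 nM in this assay, at which 2 of the 3 values shown sit, a limit and not a number. Compound 1 stands at the limit of > 5000 nM in this assay, at which 1 of the 3 values shown sits, also a limit. Within the data shown here, the single step between measured compounds, a step that the two limits leave unreadable from compound 1 to compound 2, is therefore unreadable, and no compound here has a readable number.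

Compound 4 `CC1CCN(C2CCN(S(=O)(=O)c3cnc(Cl)s3)CC2)CC1` differs from compound 3 by hydrogen in place of cyclopropyl on an aromatic carbon. Among the measured compounds shown here, no measured step touches a cyclopropyl or this ring position, so nothing among the measured steps bears on it directly. What the measurements do show is that every compound of this series, compound 1, compound 2 and compound 3, sits at a limit in this assay.

The expected step that the limit leaves unreadable from compound 3 to compound 4 is therefore none beyond the scatter, and compound 4 is expected most likely to sit at a limit as well. The estimate for compound 4 in this assay is 20000 nM, with an expected range from 8000 nM to 60000 nM.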

Compound 4, half-maximal inhibitory concentration: > 10000 nM
Compound 4: a limit, no number (the forecaster's own chance of this, stated with the estimate: 85%); the middle value lies beyond the limit too.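

In this assay compound 4 gives > 10000 nM, a limit and not a number. The steps to compound 4 from compound 3, compound 2 and compound 1 cannot be read. Whether removing the cyclopropyl or changing the group on the sulfonyl sulfur shifts the value at all stays open: no compound shown has a readable number.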